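A few compounds are considered here, and "the series" means these few. Any claim that something is new, unique, unknown or untested is made for them only; others in the source may bear on it.

Measured compounds:
compound 1 `Cc1cc(S(=O)(=O)/N=C(\N)n2nccc2-c2ccccc2)c(SCc2cccc(Cl)c2)cc1Cl` — 10000 nM
compound 2 `Cc1ccc(CSc2cc(Cl)c(C)cc2S(=O)(=O)/N=C(\N)n2nccc2-c2ccccc2)cc1` — 20000 nM
compound 3 `Cc1cc(-c2ccccc2)n(/C(N)=N/S(=O)(=O)c2cc(C)c(Cl)cc2SCc2ccc(Cl)cc2)n1` — 11000 nM

In an ADME assay on HaCaT cells (Homo sapiens) for cytotoxicity, read by MTT assay, with a stated time of 72 h (on this read-out lower numbers stand for stronger inhibition and higher numbers for weaker inhibition), compound 3 gives 11000 nM; this lies between the values of compound 1 and compound 2, and all three fall within the usual scatter of one another. Compound 4 `Cc1cc(S(=O)(=O)/N=C(\N)n2nccc2-c2ccccc2)c(SCc2ccc(Cl)cc2)cc1Cl` differs from compound 3 by hydrogen in place of methyl on an aromatic carbon. Among the measured compounds shown here, the only measured step, a 2.0-fold higher number from compound 1 to compound 2 (0.30 log units; within the scatter), changes the phenyl group on the saturated chain carbon bound to a sulfur, not the five-membered ring, so no measured step bears directly on the present change. Without such a step, the expectation for compound 4 is a value close to that of compound 3, with no change at the digits printed from compound 3 to compound 4 (within the scatter) expected to stay within the scatter. Compound 4 is therefore estimated at 11000 nM, within 5000 nM to 25000 nM.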

Compound 4, half-maximal inhibitory concentration: 12000 nM
For compound 4 the middle estimate is 1.1-fold (0.04 log units) below the measured one; measured number inside the range.
By their numbers in this assay, from the lowest: compounds 1, 3, 4 and 2 (each within the scatter of the next).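

In this assay, hydrogen in place of methyl on the aromatic carbon of the five-membered aromatic ring gives a 1.1-fold higher number from compound 3 to compound 4 (0.04 log units; within the scatter), the first read on this position, and it shows no difference beyond the scatter. 4-Chlorophenyl in place of 3-chlorophenyl gives a 1.2-fold higher number from compound 1 to compound 4 (0.08 log units; within the scatter), and chloro in place of methyl on the aromatic carbon of the phenyl group gives a 1.7-fold lower number from compound 2 to compound 4 (0.22 log units; within the scatter), so these substituent changes also stay within the scatter. No measurement available here accounts for these results. Going by these compounds, whether an amine, a carboxylic acid or a longer chain at the five-membered ring carbon would move the number beyond the scatter remains open.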